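Inverting a single stereocentre of compound 2

The compounds below may be only part of what the source reports. "The series", "measured", "known", "first", "only" and "open" are said of these compounds alone.

In a functional assay on CHO cells (Cricetulus griseus) for cytotoxicity (a higher number here means a weaker inhibitor, a lower number a stronger inhibitor), compound 1 (`Cc1ccc(S(=O)(=O)OC[C@H]2CO[C@](CCc3ccc(Cl)cc3)(Cn3ccnc3)O2)cc1`) gives 13000 nM and compound 2 (`Cc1ccc(S(=O)(=O)OC[C@@H]2CO[C@@](CCc3ccc(Cl)cc3)(Cn3ccnc3)O2)cc1`) gives 8000 nM. These two numbers sit close together, with a 1.6-fold lower number from compound 1 to compound 2 (0.21 log units; within the scatter), so compound 2 cannot be ranked apart from compound 1. The pair is linked by the fact that compounds 1 and 2 differ only in the configuration as drawn, and both of its stereocentres are inverted, which makes them mirror images.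

Compound 3 (`Cc1ccc(S(=O)(=O)OC[C@H]2CO[C@@](CCc3ccc(Cl)cc3)(Cn3ccnc3)O2)cc1`) keeps the same atoms and bonds as compound 2: the two compounds have the same atoms and bonds and differ only in configuration as drawn: 1 of 2 stereo elements differ; a stereocentre at a saturated ring carbon is drawn S in compound 2 and R in compound 3. It therefore changes only one of the two stereocentres, a kind of change not yet measured in this assay. Going by the values given here, the closest guide is the single measured step, in which inverting both stereocentres gave a 1.6-fold lower number from compound 1 to compound 2 (0.21 log units; within the scatter). That small step gives no reason to expect a large shift or a particular direction, although a one-centre change could still behave differently. The expected change is a 1.3-fold higher number from compound 2 to compound 3 (0.10 log units; within the scatter), which is no real step beyond the scatter. For compound 3 the estimated value is 10000 nM, with an expected range from 4000 nM to 25000 nM.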

Compound 3, half-maximal inhibitory concentration: 5700 nM
Beside the measured number, compound 3's estimate is 1.8-fold (0.24 log units) above it; low and high end bracket the measured number.
By their numbers in this assay, from the lowest: compounds 3, 2 and 1 (each within the scatter of the next, the first and the last beyond it).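

Going by these compounds alone, compound 3 shows for the first time what inverting one stereocentre alone does in this assay. Inverting one centre gives a 1.4-fold lower number from compound 2 to compound 3 (0.15 log units; within the scatter), so that change cannot be told apart from noise, whereas inverting the other centre gives a 2.3-fold lower number from compound 1 to compound 3 (0.36 log units; beyond the scatter), the first step in this series to clear the scatter, and a change of configuration at one centre is all that separates that pair: the fact that compounds 1 and 3 differ only in the configuration as drawn. The arrangement of these two centres can therefore shift the number in this cell test, but only modestly, and the evidence for it rests on this one step between two compounds.

The three compounds leave open how the mirror image of compound 3, the remaining arrangement of the two centres, would compare, and a single pair cannot show why one centre might count for more than the other. They also leave open whether an amine or a carboxylic acid in place of the sulfonate ester, or a longer chain in place of the two-carbon link to the chlorophenyl ring, would move the number further than configuration does.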